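This account rests on a few compounds, and the source may have more. Where it says the series, first, only, none or still open, it means among the compounds named here.

Series notes, cytotoxicity readings in a functional assay on Huh-7 cells (Homo sapiens) for cytotoxicity, read by MTT assay, with a stated time of 3 days; a higher number here means that more compound is tolerated, a lower number that less compound is tolerated.

Compound 1 `OC[C@H]1O[C@@H](n2cnc3c(COc4ccccc4)ncnc32)[C@H](O)[C@@H]1O` is the phenoxy member. In this assay compound 1 reaches only the limit, > 100000 nM. Compound 2 `OC[C@H]1O[C@@H](n2cnc3c(CSc4ccccn4)ncnc32)[C@H](O)[C@@H]1O` carries (pyridin-2-yl)sulfanyl in place of phenoxy on a saturated chain carbon bound to an aromatic carbon. In this assay compound 2 likewise returns a limit, > 100000 nM. Compound 3 `OC[C@H]1O[C@@H](n2cnc3c(CSCc4ccccc4)ncnc32)[C@H](O)[C@@H]1O` has benzylsulfanyl at that same place. In this assay compound 3 also gives a limit, > 100000 nM. Accordingly a step that the two limits leave unreadable from compound 1 to compound 2, a step that the two limits leave unreadable from compound 1 to compound 3 and a step that the two limits leave unreadable from compound 2 to compound 3 are all unreadable, the relevant fact being (the limit of > 100000 nM in this assay, at which 3 of the 3 values shown sit). Compound 2 thus stands at the limit, and the two further values shown are limits as well.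

Compound 4 `OC[C@H]1O[C@@H](n2cnc3c(CSc4ccccc4)ncnc32)[C@H](O)[C@@H]1O` is the unmeasured member: phenyl in place of pyridin-2-yl on a sulfur. For the measured compounds named here, the only step that also alters the group on the sulfur, a step that the two limits leave unreadable from compound 2 to compound 3, cannot be sized. No readable step exists, so the expectation for compound 4 is another limit rather than a number. The step to compound 4 is expected as a number no higher from compound 2 to compound 4 (the limit leaves the size open). For compound 4 the estimate in this assay is 100000 nM, within 60000 nM to 300000 nM.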

Compound 4, half-maximal cytotoxic concentration: > 100000 nM
Compound 4 gave a limit, no number (the forecaster's own chance of this, stated with the estimate: 85%); the middle value lies on the limit itself.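

Compound 4 gives only a limit in this assay, > 100000 nM. Its steps to compound 1, compound 2 and compound 3 therefore cannot be read: the limit of > 100000 nM in this assay, at which 4 of the 4 values shown sit.

The compounds shown leave open whether any group at this place gives a number rather than a limit in this assay.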